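This account rests on a few compounds, and the source may have more. Where it says the series, first, only, none or still open, it means among the compounds named here.

Measured compounds:
Compound 1 `CC1=C(C(C)C(=O)NCCN2CCNCC2)c2cc(F)ccc2/C1=C\c1ccc([S+](C)[O-])cc1` — in a functional assay on HT-29 cells (Homo sapiens) for inhibition, read by CellTiter-Glo, with a stated time of 72 h (on this read-out lower numbers stand for higher toxicity in this test and higher numbers for lower toxicity in this test), compound 1 stops at the limit > 50000 nM.
Compound 2 `CC1=C(C(C)C(=O)N2CCN(CCN(C)C)CC2)c2cc(F)ccc2/C1=C\c1ccc([S+](C)[O-])cc1` — in this assay compound 2 gives 38400 nM.

Within the data shown here, compound 2 stands as the only compound with a number in this assay; the other value shown is a limit, not a number. Compound 3 `CC1=C(C(C)C(=O)N2CCN(CCCN(C)C)CC2)c2cc(F)ccc2/C1=C\c1ccc([S+](C)[O-])cc1` differs from compound 2 by (dimethylamino)methyl in place of dimethylamino on a saturated chain carbon, two bonds along the chain from an amine nitrogen in a ring. Among the measured compounds shown here, only one measured step exists, an at least 1.3-fold lower number from compound 1 to compound 2 (0.11 log units; that floor lies within the scatter), and it concerns the substituent on the carbonyl carbon rather than the chain that is lengthened here; its floor lies within the scatter, and one of the two values sits at the limit of > 50000 nM in this assay, at which 1 of the 2 values shown sits. For the measured compounds named here, no measured step therefore bears on the lengthening of the chain, and the account expects no step beyond the scatter, so a 1.0-fold lower number from compound 2 to compound 3 (0.00 log units; within the scatter) is the estimated change. Compound 3 is expected to give 38000 nM, with a range from 15000 nM to 90000 nM.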

Compound 3, half-maximal cytotoxic concentration: 32000 nM
The estimate for compound 3 lay 1.2-fold (0.07 log units) above the measured number; measured number inside the range.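

In this assay, (dimethylamino)methyl in place of dimethylamino on a saturated chain carbon, two bonds along the chain from an amine nitrogen in a ring, gives a 1.2-fold lower number from compound 2 to compound 3 (0.08 log units; within the scatter). Among these compounds, this is the only measured step at this place, and it shows that the 2-(dimethylamino)ethyl and 3-(dimethylamino)propyl chains cannot be told apart in this read-out. The wider change gives an at least 1.5-fold lower number from compound 1 to compound 3 (0.19 log units; that floor lies within the scatter), which offers only a floor, so its true size cannot be read: the limit of > 50000 nM in this assay, at which 1 of the 3 values shown sits.

The compounds shown leave open whether a longer chain, such as 4-(dimethylamino)butyl, would move the number beyond the scatter. They also leave open whether a morpholine or a primary amine at the end of the chain would do so.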